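Aryl replacing benzyl on the piperazine nitrogen

The source may report more compounds than this note shows. Statements on the series, on what has been measured and on what is new or still open speak of the compounds shown alone.

Compound 1 `COc1ccccc1C(=O)Nc1ccc(N2CCN(Cc3ccccc3)CC2)cc1C(=O)O` carries a benzyl group on the ring amine nitrogen. In a toxicity assay on L3.6pl cells (Homo sapiens) for inhibition, read by ATP content, with a stated time of 72 h (a higher number here means a weaker inhibitor, a lower number a stronger inhibitor), compound 1 gives only a limit, > 10000 nM, and not a number. Compound 3 `COc1ccccc1C(=O)Nc1ccc(CN2CCN(c3ccccn3)CC2)cc1C(=O)O` likewise reaches only a limit in this assay, > 10000 nM. Among the compounds with values here, compound 2 `COc1ccc(C(=O)Nc2ccc(N3CCN(c4ccccc4Cl)CC3)cc2C(=O)O)cc1`, the one compound of the three with a number, gives 125000 nM in this assay, so no measured compound here reads as a strong inhibitor. Within the data shown here, the shared limit of > 10000 nM in this assay, at which 2 of the 3 values shown sit, covers two of the three values and leaves no measured step to rest on.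

Compound 4 `COc1ccccc1C(=O)Nc1ccc(N2CCN(c3cc(Cl)ccc3C)CC2)cc1C(=O)O` is the next member. It differs from compound 1 in one place: 5-chloro-2-methylphenyl in place of benzyl on an amine nitrogen in a ring. Of the three measured compounds, compound 2 is the one that also carries an aryl group on that ring nitrogen, and its value in this assay is weak. Given that, and the limit of compound 1, no step beyond the scatter is expected in this assay; the series is expected to stay weak. Compound 4 is therefore estimated at 50000 nM, with a range from 10000 nM to 250000 nM, and the implied step that the limit leaves unreadable from compound 1 to compound 4 is expected to carry little weight, since a limit, not a number, stands behind compound 1.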

Compound 4, half-maximal inhibitory concentration: 29100 nM
Compound 4: the middle estimate sits 1.7-fold (0.24 log units) above what was measured; measured number inside the range.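

No step can be read from compound 1 to compound 4, because the value of compound 1 is a limit and not a number: the limit of > 10000 nM in this assay, at which 2 of the 4 values shown sit.

Still open is whether 5-chloro-2-methylphenyl in place of benzyl on the ring amine nitrogen shifts the reading in this assay, since no two compounds shown that differ in one place both carry a number.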